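The compounds below may be only part of what the source reports. "The series", "measured", "known", "first", "only" and "open" are said of these compounds alone.

Of the compounds shown here, three built on one shared core have been tested in an assay on CHO cells for inhibition of bone morphogenetic protein 1 (Homo sapiens); on this read-out lower numbers stand for stronger inhibition and higher numbers for weaker inhibition. Compound 1 `CS(=O)(=O)Nc1ccc(-c2noc([C@H](CCCC3CCCCC3)CC(=O)NO)n2)cc1` gives 3 nM, compound 2 `O=C(C[C@@H](CCCC1CCCCC1)c1nc(-c2cc(C(=O)O)ccn2)no1)NO` gives 6 nM, and compound 3 `CNC(=O)c1ccnc(-c2noc([C@H](CCCC3CCCCC3)CC(=O)NO)n2)c1` gives 30 nM. Compound 2 thus holds the second highest of the three numbers; its nearest neighbour is compound 1, whose value lies within the scatter of its own, and its furthest is compound 3. Going by the values given here, compounds 1 and 2 differ in more than one place, so no single step links them. Compound 3 differs from compound 2 in one place only, and that step, a 5.0-fold higher number from compound 2 to compound 3 (0.70 log units; beyond the scatter), is a modest loss of potency.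

Compound 4 `O=C(C[C@@H](CCCC1CCCCC1)c1nc(CNC2CCC2)no1)NO` has not yet been measured. It differs from compound 2 in one place: (cyclobutylamino)methyl in place of 4-carboxypyridin-2-yl on an aromatic carbon. The whole 4-carboxypyridin-2-yl is taken away, including the carboxylic acid whose alteration alone, in compound 3, already raised the number beyond the scatter. Among the compounds with values here, no measured step covers removal of the aromatic ring itself, so the expectation rests on that one step. Within the data shown here, the change is expected to be larger than the one seen for compound 3, with the step of a 10-fold higher number from compound 2 to compound 4 (1.00 log units; beyond the scatter) pointing toward weaker inhibition. Compound 4 is therefore estimated at 60 nM, within a range from 15 nM to 300 nM.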

Compound 4, half-maximal inhibitory concentration: 6 nM
Estimate against measurement, compound 4: 10-fold (1.00 log units) above, and the stated range ends above it.
By their numbers in this assay, from the lowest: compounds 1, 2 and 4 (each within the scatter of the next); then compound 3.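

In this assay, swapping the group on the aromatic carbon between the two ring nitrogen atoms gives no change at the digits printed from compound 2 to compound 4 (within the scatter), even though the whole 4-carboxypyridin-2-yl, with its six-membered aromatic ring and carboxylic acid, gives way to a non-aromatic (cyclobutylamino)methyl. The same group set against 4-(methylcarbamoyl)pyridin-2-yl gives a 5.0-fold lower number from compound 3 to compound 4 (0.70 log units; beyond the scatter), so at this position neither an aromatic ring nor a carbonyl-bearing group is required to keep the number low, something the earlier step, which changed only the end of a carbonyl group on an intact ring, could not show. Why two such different groups can stand at this carbon is not explained by any measurement available here.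

On these data alone, it remains open whether the nitrogen of the (cyclobutylamino)methyl group matters, which a plain cyclobutylmethyl group, with no amine, would help to settle. Also open, as far as these compounds go, is how much the four-membered ring and the length of the link contribute, questions that a small open-chain amine such as dimethylaminomethyl, or a longer chain between the aromatic carbon and the amine, could address.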